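Chlorophenyl triazole sulfonamides against A549 cells

The compounds below may be only part of what the source reports. "The series", "measured", "known", "first", "only" and "open" are said of these compounds alone.

Of the compounds shown here, three sharing a sulfonamide-linked triazole scaffold have been measured in a functional assay on A549 cells (Homo sapiens) for antiproliferative activity, read by MTT assay, with a stated time of 24 h; on this read-out lower numbers stand for stronger inhibition and higher numbers for weaker inhibition. Compound 1, `O=c1[nH]cc(S(=O)(=O)Nc2cccc(-c3cn(-c4cccc(Cl)c4)nn3)c2)c(=O)[nH]1`, gives 2430 nM in this assay. Compound 2, `O=c1[nH]cc(S(=O)(=O)Nc2cccc(-c3cn(-c4ccc(Cl)cc4)nn3)c2)c(=O)[nH]1`, gives 1730 nM in this assay. These two differ in one place, (4-chlorophenyl in place of 3-chlorophenyl on an aromatic nitrogen), and the step is a 1.4-fold lower number from compound 1 to compound 2 (0.15 log units; within the scatter). Compound 3, `O=c1[nH]cc(S(=O)(=O)Nc2ccc(-c3cn(-c4cccc(Cl)c4)nn3)cc2)c(=O)[nH]1`, gives 2310 nM in this assay; the difference between the core of compound 3 and the core of compound 1 is not broken down here, and the two values sit close to one another within the usual scatter.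

Compound 4, `O=c1[nH]cc(S(=O)(=O)Nc2ccc(-c3cn(-c4ccc(Cl)cc4)nn3)cc2)c(=O)[nH]1`, has not yet been measured in this assay. It differs from compound 3 in one place, (4-chlorophenyl in place of 3-chlorophenyl on an aromatic nitrogen). This is the same change that was made from compound 1 to compound 2, occurring twice in all among the compounds shown, and the surroundings of the place are the same in both pairs.

For the measured compounds named here, since the one measured instance of this change, a 1.4-fold lower number from compound 1 to compound 2 (0.15 log units; within the scatter), stayed within the scatter, compound 4 is expected to land close to compound 3, and the step from compound 3 to compound 4 is estimated as a 1.4-fold lower number from compound 3 to compound 4 (0.13 log units; within the scatter) in this assay. On that basis compound 4 is estimated to give 1700 nM in this assay, with a likely range from 900 nM to 3200 nM.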

Compound 4, half-maximal inhibitory concentration: 1210 nM
Beside the measured number, compound 4's estimate is 1.4-fold (0.15 log units) above it; measured number inside the range.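

In this assay, exchanging 3-chlorophenyl for 4-chlorophenyl on the aromatic nitrogen of the second core gives a 1.9-fold lower number from compound 3 to compound 4 (0.28 log units; within the scatter), and this step can be set beside its counterpart on the first core, where the surroundings of the place are the same: the same change on two cores in this assay, a 1.4-fold lower number (0.15 log units; within the scatter) from compound 1 to compound 2 and a 1.9-fold lower number (0.28 log units; within the scatter) from compound 3 to compound 4, 1.4-fold (0.13 log units) apart, within the scatter of two such steps. This shows that, across these two cores, the change carries over with no difference that can be told from the scatter, so the two steps are consistent with one another. It does not show that 4-chlorophenyl truly outperforms 3-chlorophenyl on either core, since each step on its own lies within the scatter, and two pairs in a single assay cannot establish that the change would behave the same way on any further core.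

The compounds shown leave open whether the group on the aromatic nitrogen matters at all in this assay, as both groups here are chlorophenyl isomers with the same atoms. A plain phenyl, or a phenyl carrying a methoxy group, an amine or a carboxylic acid in place of the chlorine, would test this more widely than moving the chlorine does.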